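A few compounds are considered here, and "the series" means these few. Any claim that something is new, unique, unknown or untested is made for them only; others in the source may bear on it.

Of the compounds shown here, three sharing one core have been tested for how strongly they harm a human cell line. Among the compounds with values here, compound 1 `COc1cccc(NC(=O)c2ccc3cccc(O)c3n2)c1` is the first of them. In an ADME assay on THP-1 cells (Homo sapiens) for cytotoxicity, read by WST assay, with a stated time of 24 h (on this read-out lower numbers stand for stronger inhibition and higher numbers for weaker inhibition), compound 1 gives > 30000 nM, which is a limit of the assay rather than a measured number. Compound 2 `Cc1ccccc1NC(=O)c1ccc2cccc(O)c2n1` gives > 30000 nM in this assay, again a limit. Compound 3 `O=C(Nc1ccccc1F)c1ccc2cccc(O)c2n1` gives > 30000 nM in this assay, also a limit. Because both values are limits, the step that the two limits leave unreadable from compound 2 to compound 3 cannot be read. Compound 2 therefore stands at the limit, and every value shown sits there (the limit of > 30000 nM in this assay, at which 3 of the 3 values shown sit).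

Compound 4 `O=C(Nc1cccc(Br)c1)c1ccc2cccc(O)c2n1` differs from compound 2 in one place: 3-bromophenyl in place of 2-methylphenyl on an amide-type nitrogen. Within the data shown here, the only measured step that alters the same part of the molecule, a step that the two limits leave unreadable from compound 2 to compound 3, gives neither size nor direction. Among the measured compounds shown here, no measured step suggests that compound 4 would move away from the limit. The expected step is a number no higher from compound 2 to compound 4 (the limit leaves the size open), nothing beyond the scatter. For compound 4 the estimate in this assay is 30000 nM, with a range from 15000 nM to 100000 nM.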

Compound 4, half-maximal inhibitory concentration: > 30000 nM
Compound 4: a limit, no number; the forecaster's own chance of this, stated with the estimate: 80%; the middle value lies on the limit itself.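

Compound 4 gives > 30000 nM in this assay, again a limit of the assay rather than a number. Its steps from compound 1, compound 2 and compound 3 therefore cannot be read: the limit of > 30000 nM in this assay, at which 4 of the 4 values shown sit. The compounds shown leave open which change on the amide-type nitrogen, if any, would give a readable number in this assay.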